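The source may report more compounds than this note shows. Statements on the series, on what has been measured and on what is new or still open speak of the compounds shown alone.

Measured in a functional assay on MCF7 cells (Homo sapiens) for antiproliferative activity, read by MTT assay, with a stated time of 48 h (on this read-out lower numbers stand for stronger inhibition and higher numbers for weaker inhibition), are three compounds:
Compound 1 `Cc1ccc(S(=O)(=O)n2cc(/C=C/C(=O)c3ccncc3)c3ccccc32)cc1` gives 48900 nM
Compound 2 `COc1ccc(S(=O)(=O)n2cc(/C=C/C(=O)c3ccncc3)c3ccccc32)cc1` gives 65800 nM
Compound 3 `O=C(/C=C/c1cn(S(=O)(=O)c2cccc3ccccc23)c2ccccc12)c1ccncc1` gives 58000 nM

Compound 1 lies within the usual scatter of both other compounds. Compound 4 `CCCS(=O)(=O)n1cc(/C=C/C(=O)c2ccncc2)c2ccccc21` has propyl in place of 4-methylphenyl on a sulfonyl sulfur. The closest evidence comes from swaps at that same sulfur (a 1.2-fold higher number from compound 1 to compound 3 (0.07 log units; within the scatter)) and (a 1.1-fold lower number from compound 2 to compound 3 (0.05 log units; within the scatter)), while methoxy in place of methyl gives a similarly small step (a 1.3-fold higher number from compound 1 to compound 2 (0.13 log units; within the scatter)). For the measured compounds named here, all of these keep an aromatic group on the sulfur, and no measured compound carries propyl, so the evidence is indirect. No step beyond the scatter is therefore expected in this assay for this change. The expected step is a 1.2-fold higher number from compound 1 to compound 4 (0.09 log units; within the scatter) and no more. Compound 4 is estimated at 60000 nM with an expected range of 25000 nM to 130000 nM on this read-out.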

Compound 4, half-maximal inhibitory concentration: 52400 nM
Compound 4: middle estimate off by 1.1-fold (0.06 log units), on the high side, and the stated range covers the measured number.
By their numbers in this assay, from the lowest: compounds 1, 4, 3 and 2 (each within the scatter of the next).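

In this assay swapping the aromatic group on the sulfonyl sulfur for propyl gives a 1.1-fold higher number from compound 1 to compound 4 (0.03 log units; within the scatter) and a 1.1-fold lower number from compound 3 to compound 4 (0.04 log units; within the scatter) and a 1.3-fold lower number from compound 2 to compound 4 (0.10 log units; within the scatter) in turn. Among these four compounds, then, a ring on this sulfur is not required to keep the number within the scatter, even though propyl has no ring and fewer heavy atoms than 4-methylphenyl. No measurement shown gives a reason for this. As far as these compounds go, whether a longer chain, or a propyl chain ending in an amine or a carboxylic acid, would move the number beyond the scatter stays open.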